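Working notes: aryl exchange from compound 3 to compound 4

The source may hold more compounds than are shown below. What is called first, only, known or untested is meant among the compounds shown, and "the series" means these compounds.

Measured so far:
- compound 1 `COc1cccc(C(=O)NN(C(=O)c2ccccc2Cl)C(C)(C)C)c1`: 52.5 nM in an assay on cells for agonist activity at ecdysone receptor (Bombyx mori), read by a luciferase reporter, with a stated time of 24 h; on this read-out higher numbers stand for an effect only at larger amounts of compound and lower numbers for an effect already at smaller amounts
- compound 2 `CC(C)(C)N(NC(=O)c1ccc(Cl)cc1)C(=O)c1ccccc1Cl`: 115 nM in this assay
- compound 3 `COc1cccc(C(=O)NN(C(=O)c2cc(C)cc(C)c2)C(C)(C)C)c1`: 66.1 nM in this assay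

Compound 3 gives the second highest of the three numbers. Against compound 1 the difference is a 1.3-fold higher number from compound 1 to compound 3 (0.10 log units; within the scatter), within the scatter; against compound 2 the two values also sit within the scatter of each other, so no order can be read there.

Compound 4 `Cc1cc(C)cc(C(=O)N(NC(=O)c2ccc(Cl)cc2)C(C)(C)C)c1` differs from compound 3 by 4-chlorophenyl in place of 3-methoxyphenyl on a carbonyl carbon. The same exchange has been measured once, from compound 1 to compound 2: a 2.2-fold higher number from compound 1 to compound 2 (0.34 log units; beyond the scatter). On that basis a modest upward step is expected, a 2.2-fold higher number from compound 3 to compound 4 (0.34 log units; beyond the scatter). For compound 4 the estimate in this assay is 145 nM, with a range from 70 nM to 300 nM.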

Compound 4, half-maximal effective concentration: 19.1 nM
Estimate against measurement, compound 4: 7.6-fold (0.88 log units) above; the measured number lies below the stated range.
By their numbers in this assay, from the lowest: compound 4; then compounds 1, 3 and 2 (each within the scatter of the next, the first and the last beyond it).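

In this assay, the exchange of 3-methoxyphenyl for 4-chlorophenyl on a carbonyl carbon now gives a 3.5-fold lower number from compound 3 to compound 4 (0.54 log units; beyond the scatter), so its direction depends on the aryl group on the other carbonyl: the same change on two cores in this assay, a 2.2-fold higher number (0.34 log units; beyond the scatter) from compound 1 to compound 2 and a 3.5-fold lower number (0.54 log units; beyond the scatter) from compound 3 to compound 4, 7.6-fold (0.88 log units) apart, beyond the scatter of two such steps. The exchange of 2-chlorophenyl for 3,5-dimethylphenyl, within the scatter on the core of compound 1, gives a 6.0-fold lower number from compound 2 to compound 4 (0.78 log units; beyond the scatter) with 4-chlorophenyl present: the same change on two cores in this assay, a 1.3-fold higher number (0.10 log units; within the scatter) from compound 1 to compound 3 and a 6.0-fold lower number (0.78 log units; beyond the scatter) from compound 2 to compound 4, 7.6-fold (0.88 log units) apart, beyond the scatter of two such steps. Across these four compounds, the two aryl groups therefore do not contribute independently.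

Still open, from the compounds shown here alone, is whether an amine or a carboxylic acid in place of the chlorine of compound 4 would retain its number.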